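The compounds below may be only part of what the source reports. "The series", "measured", "known", "first", "only" and "open" are said of these compounds alone.

Of the compounds shown here, two built on the same core have been tested so far in a functional assay on HUVEC cells (Homo sapiens) for inhibition, with a stated time of 4 days; a lower number here means a stronger inhibitor, a higher number a weaker inhibitor. Compound 1 (`COc1ccc(C(N)=O)cc1/C=C/c1ccc(C(C)(C)C)cc1`), which carries a tert-butyl group, gives 370 nM. Compound 2 (`COc1ccc(C(N)=O)cc1/C=C/c1ccc(C(F)(F)F)cc1`), with trifluoromethyl in place of tert-butyl, gives 880 nM, the higher number of the two and therefore the weaker inhibitor.

The next molecule, compound 3 (`COc1ccc(C(N)=O)cc1/C=C/c1ccc(C)cc1`), keeps the core and has methyl in place of trifluoromethyl on an aromatic carbon. Among the compounds with values here, only one measured step bears on this change, a 2.4-fold higher number from compound 1 to compound 2 (0.38 log units; beyond the scatter). That step was modest, and it also involved swapping one group for another on an aromatic carbon. It is thin evidence, however, since methyl has not yet been measured on this core. Given the modest size of that single step, a large change would be surprising here, and only a slight move toward a lower number is expected, not one beyond the scatter. The expected change is a 1.3-fold lower number from compound 2 to compound 3 (0.10 log units; within the scatter). For compound 3 the estimated value is 700 nM, with an expected range of 280 nM to 1800 nM.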

Compound 3, half-maximal inhibitory concentration: 1600 nM
Estimate against measurement, compound 3: 2.3-fold (0.36 log units) below; the measured number falls inside the stated range.
By their numbers in this assay, from the lowest: compound 1; then compounds 2 and 3 (each within the scatter of the next).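

In this assay, methyl in place of trifluoromethyl gives a 1.8-fold higher number from compound 2 to compound 3 (0.26 log units; within the scatter), so this change does not separate compound 2 from compound 3, even though methyl has 1 heavy atom and trifluoromethyl has 4. Methyl in place of tert-butyl gives a 4.3-fold higher number from compound 1 to compound 3 (0.64 log units; beyond the scatter), and together with a 2.4-fold higher number from compound 1 to compound 2 (0.38 log units; beyond the scatter) this shows that, among these three compounds, tert-butyl alone stands apart at this position, with compound 1 as the strongest inhibitor. No measurement available here explains why tert-butyl stands apart from the other two groups.

The three compounds leave open how a plain hydrogen, an isopropyl group, a methoxy group or an amine would compare at this same position, and so whether tert-butyl is a special case or one point in a wider trend. They also leave open how much the methoxy group and the primary amide on the other side of the shared core contribute, since both stay the same in all three compounds.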